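Amine substituents on the shared core: estimating compound 4

A few compounds are considered here, and "the series" means these few. Any claim that something is new, unique, unknown or untested is made for them only; others in the source may bear on it.

Measured so far:
compound 1 `CCCN(CCC(F)(F)F)Cc1c(C(F)(F)F)nc2n(-c3c(C)cc(C)cc3C)c(Cl)cn12` — 12 nM
compound 2 `C=CCN(CCC)Cc1c(C(F)(F)F)nc2n(-c3c(C)cc(C)cc3C)c(Cl)cn12` — 4.5 nM
compound 3 `CCCN(Cc1c(C(F)(F)F)nc2n(-c3c(C)cc(C)cc3C)c(Cl)cn12)CC1CCC1` — 5.3 nM

In an assay on cells for displacement of a labelled ligand from corticotropin-releasing factor receptor 1 (Homo sapiens), with a stated time of 100 min (on this read-out lower numbers stand for stronger inhibition and higher numbers for weaker inhibition), compound 1 gives 12 nM, the highest of the three numbers; compound 3 lies nearest to it and compound 2 furthest. Both measured steps alter the trifluoroethyl arm on the amine nitrogen: a 2.7-fold lower number from compound 1 to compound 2 (0.43 log units; beyond the scatter) and a 2.3-fold lower number from compound 1 to compound 3 (0.35 log units; beyond the scatter), each modest but beyond the scatter. Between the two replacements themselves, a 1.2-fold higher number from compound 2 to compound 3 (0.07 log units; within the scatter) is within the scatter, so compounds 2 and 3 cannot be ranked.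

Compound 4 `Cc1cc(C)c(-n2c(Cl)cn3c(CN(CCC4CC4)CCC(F)(F)F)c(C(F)(F)F)nc23)c(C)c1` keeps the trifluoroethyl arm of compound 1 and instead changes the other arm: cyclopropyl in place of methyl on a saturated chain carbon, two bonds along the chain from an amine nitrogen, that is, propyl becomes 2-cyclopropylethyl. Among the compounds with values here, no measured step touches this arm, so the two steps from compound 1 bear on it only indirectly, in showing that the amine substituents of this core accept modest enlargement without loss. A change of at most modest size in either direction is therefore expected, most likely within the scatter. Compound 4 is estimated at 10 nM, with a range of 4 nM to 25 nM, which corresponds to an expected 1.2-fold lower number from compound 1 to compound 4 (0.08 log units; within the scatter).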

Compound 4, inhibition constant: 110 nM
Estimate against measurement, compound 4: 11-fold (1.04 log units) below; measured number above the stated range.
By their numbers in this assay, from the lowest: compounds 2 and 3 (each within the scatter of the next); then compound 1; then compound 4.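

In this assay, within the data shown here, the first change to the propyl arm on the amine nitrogen goes against the earlier picture: a 9.2-fold higher number from compound 1 to compound 4 (0.96 log units; beyond the scatter) is a larger step than either a 2.7-fold lower number from compound 1 to compound 2 (0.43 log units; beyond the scatter) or a 2.3-fold lower number from compound 1 to compound 3 (0.35 log units; beyond the scatter) and runs the opposite way. Accepted enlargement of the trifluoroethyl arm therefore does not carry over to the other arm, and with the trifluoroethyl arm kept, propyl to 2-cyclopropylethyl is the only one of the listed changes that raises the number. No measurement at hand accounts for the size of this step.

As far as these compounds go, it remains open whether the step follows from the three-membered ring itself or from the added carbons, a question that an open chain such as pentyl or isopentyl on the same arm, or a shorter arm such as ethyl or cyclopropylmethyl, would address. From the compounds shown here alone, it is also open whether the 2-cyclopropylethyl arm behaves the same way when the vinyl or cyclobutyl replacement stands in place of 2,2,2-trifluoroethyl on the other arm, and whether a hydroxyl or an ether oxygen in the chain changes the outcome.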